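The source may report more compounds than this note shows. Statements on the series, on what has been measured and on what is new or still open speak of the compounds shown alone.

Measured in a functional assay on MCF7 cells (Homo sapiens) for inhibition, read by MTT assay, with a stated time of 24 h; a higher number here means a weaker inhibitor of growth, a lower number a stronger inhibitor of growth:
Compound 1 `Cn1cc(-c2nc3ccccc3n2C(=O)c2ccccc2)c2ccccc21`: 43700 nM
Compound 2 `COc1ccc(C(=O)n2c(-c3cn(C)c4ccccc34)nc3ccccc32)cc1`: 16300 nM
Compound 3 `COc1ccc(C(=O)n2c(-c3cn(C)c4ccccc34)nc3ccccc32)cc1OC`: 10200 nM

Among these three numbers, the series shows a 4.3-fold lower number from compound 1 to compound 3 (0.63 log units; beyond the scatter), a modest change that clears the scatter. The nearest value gives a 1.6-fold lower number from compound 2 to compound 3 (0.20 log units; within the scatter), which stays inside the scatter, so those two compounds cannot be ranked against each other.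

The next compound, compound 4 `COc1cc(C(=O)n2c(-c3cn(C)c4ccccc34)nc3ccccc32)cc(OC)c1OC`, has one further change: methoxy in place of hydrogen on an aromatic carbon. Two measured steps are of this same kind. The first is a 2.7-fold lower number from compound 1 to compound 2 (0.43 log units; beyond the scatter), which is modest. The second is again a 1.6-fold lower number from compound 2 to compound 3 (0.20 log units; within the scatter), which cannot be told from no change. Both point towards a lower number, but only the first lies beyond the scatter, and two steps make a thin basis for a trend. A small further drop in this assay is therefore expected, quite possibly one that stays within the scatter. The expected change is a 1.4-fold lower number from compound 3 to compound 4 (0.13 log units; within the scatter). Compound 4 is estimated at 7500 nM, with an expected range from 3000 nM to 16000 nM.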

Compound 4, concentration for 50% growth inhibition: 5400 nM
Estimate against measurement, compound 4: 1.4-fold (0.14 log units) above; measured number inside the range.
By their numbers in this assay, from the lowest: compounds 4, 3 and 2 (each within the scatter of the next, the first and the last beyond it); then compound 1.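

In this assay, a further methoxy on an aromatic carbon, ortho to a methoxy group and meta to a large group, gives a 1.9-fold lower number from compound 3 to compound 4 (0.28 log units; within the scatter), so this step on its own cannot be told from no change. Its size also cannot be separated from that of the first methoxy step, even though the two steps stand on different cores and only the first clears the scatter: the same change on two cores in this assay, a 2.7-fold lower number (0.43 log units; beyond the scatter) from compound 1 to compound 2 and a 1.9-fold lower number (0.28 log units; within the scatter) from compound 3 to compound 4, 1.4-fold (0.15 log units) apart, within the scatter of two such steps Of the three methoxy steps now in hand, only a 2.7-fold lower number from compound 1 to compound 2 (0.43 log units; beyond the scatter) stands clear, while a 1.6-fold lower number from compound 2 to compound 3 (0.20 log units; within the scatter) and the new step both stay inside the scatter, so the added methoxy at this position shows no separate effect of its own.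

The compounds shown leave open how a hydroxy group, an amine or a longer chain such as ethoxy would read at this position, where only hydrogen and methoxy are seen so far. They also leave open what a methoxy at this position gives on its own, without the other methoxy groups on the ring.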